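Aryl swap on the aromatic nitrogen of the series

The compounds below may be only part of what the source reports. "The series", "measured", "known", "first", "only" and "open" are said of these compounds alone.

Compound 1 `N#CC1=C(N)Oc2c(c3nc4ccccc4nc3c3ccccc23)C12C(=O)N(Cc1cnnn1-c1ccc([N+](=O)[O-])cc1)c1ccccc12` gives in a functional assay on HepG2 cells (Homo sapiens) for antiproliferative activity, read by MTT assay, with a stated time of 48 h (a higher number here means a weaker inhibitor, a lower number a stronger inhibitor), only a limit, > 50000 nM, not a number. Compound 2 `CC(=O)Nc1ccc(-n2nncc2CN2C(=O)C3(C(C#N)=C(N)Oc4c(N)cc5nc6ccccc6nc5c43)c3ccccc32)cc1` likewise sits at a limit in this assay, > 50000 nM. Going by the values given here, both results thus rest at the limit of > 50000 nM in this assay, at which 2 of the 2 values shown sit, so compound 2 stands nowhere on a measured scale and no step between measured compounds is available. Compound 3 `CCc1cccc(CC)c1-n1nncc1CN1C(=O)C2(C(C#N)=C(N)Oc3c(N)cc4nc5ccccc5nc4c32)c2ccccc21` carries 2,6-diethylphenyl in place of 4-acetamidophenyl on an aromatic nitrogen. With both known values at the limit, any change is expected to lie within the scatter, a step that the limit leaves unreadable from compound 2 to compound 3. Compound 3 is therefore estimated at 60000 nM, within 20000 nM to 200000 nM, and is expected most likely to be reported again only as a limit.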

Compound 3, half-maximal inhibitory concentration: 16500 nM
Estimate against measurement, compound 3: 3.6-fold (0.56 log units) above; the whole stated range lies above it.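

In this assay compound 3 gives 16500 nM as a measured value, so the aryl group on the aromatic nitrogen can bring the read-out off the limit (an at least 3.0-fold lower number from compound 2 to compound 3 (0.48 log units; beyond the scatter)). With the shared core unchanged, 2,6-diethylphenyl and 4-acetamidophenyl read differently at this position. The size of the step remains a lower bound, as the value of compound 2 is a limit: the limit of > 50000 nM in this assay, at which 2 of the 3 values shown sit.

From the compounds shown here alone, whether the step follows the two ethyl groups or the loss of the acetamido group remains open. A 2,6-dimethylphenyl or plain phenyl group at this position could separate the two.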